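Phenyl in Place of Hydroxymethyl: Expecting Compound 4

A few compounds are considered here, and "the series" means these few. Any claim that something is new, unique, unknown or untested is made for them only; others in the source may bear on it.

Measured so far:
compound 1 `CCCNC(=O)C1CCN(C(=O)c2cc3sc(CNC(C)c4ccccc4)cc3n2Cc2ccc(OC)cc2)CC1`: 33900 nM
compound 2 `CCCNC(=O)C1CCN(C(=O)c2cc3sc(CNCc4ccccc4)cc3n2Cc2ccc(OC)cc2)CC1`: 46800 nM
compound 3 `CCCNC(=O)C1CCN(C(=O)c2cc3sc(CO)cc3n2Cc2ccc(OC)cc2)CC1`: 15500 nM

In an ADME assay on HEK-293T cells (Homo sapiens) for cytotoxicity, read by luminescence, with a stated time of 24 h (a lower number here means that less compound is tolerated, a higher number that more compound is tolerated), compound 3 stands lowest of the three: the step of a 2.2-fold lower number from compound 1 to compound 3 (0.34 log units; beyond the scatter) and the step of a 3.0-fold lower number from compound 2 to compound 3 (0.48 log units; beyond the scatter) both run downward to it, beyond the scatter. Compound 4 `CCCNC(=O)C1CCN(C(=O)c2cc3sc(-c4ccccc4)cc3n2Cc2ccc(OC)cc2)CC1` arises from compound 3 by phenyl in place of hydroxymethyl on an aromatic carbon. Only those two steps bear on this change, and both show that replacing hydroxymethyl with a group carrying a phenyl went with a modestly higher number. Phenyl alone, without the amine, is untested, so the expected step of a 1.5-fold higher number from compound 3 to compound 4 (0.19 log units; within the scatter) is modest and upward, near the edge of the scatter. Compound 4 is therefore estimated at 24000 nM in this assay, within a range from 9000 nM to 60000 nM.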

Compound 4, half-maximal cytotoxic concentration: > 100000 nM
Compound 4 ended at the assay's limit (the forecaster's own chance of this, stated with the estimate: 10%); at least 4.1-fold (0.61 log units) between middle value and limit.
By their numbers in this assay, from the lowest: compound 3; then compounds 1 and 2 (each within the scatter of the next). At a limit, above all of these: compound 4.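

Compound 4 gives a limit of the assay rather than a number in this assay: the limit of > 100000 nM in this assay, at which 1 of the 4 values shown sits.

On this aromatic carbon next to the ring sulfur, phenyl placed directly on the ring goes with far more tolerated compound than hydroxymethyl, with an at least 6.4-fold higher number from compound 3 to compound 4 (0.80 log units; beyond the scatter). The amine-bearing groups fall short of it too, with an at least 2.1-fold higher number from compound 2 to compound 4 (0.32 log units; beyond the scatter) and an at least 2.9-fold higher number from compound 1 to compound 4 (0.46 log units; beyond the scatter), so a phenyl needs no amine link to give a high number here.

Going by these compounds, whether this is specific to phenyl stays open: a methyl, a cyclohexyl or a pyridine ring on the same carbon could behave alike or differently.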